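From Triazole to Tetrazole on a Shared Core

The compounds below may be only part of what the source reports. "The series", "measured", "known", "first", "only" and "open" are said of these compounds alone.

Three compounds have been measured in an assay for inhibition of Aromatase (Homo sapiens); on this read-out lower numbers stand for stronger inhibition and higher numbers for weaker inhibition:

Compound 1, `Fc1ccc(C(C2Cc3ccccc3O2)n2cncn2)cc1`, gives 190 nM
Compound 2, `Cc1ccc(C(C2Cc3ccccc3O2)n2cncn2)cc1`, gives 590 nM
Compound 3, `Clc1ccc(C(C2Cc3ccccc3O2)n2cncn2)c(Cl)c1`, gives 880 nM

Compound 3 has the highest number of the three. Against compound 2 the gap lies within the scatter, so the two cannot be ordered; against compound 1 the gap is beyond the scatter, so compound 3 is clearly the weaker of that pair.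

Compound 4, `Clc1ccc(C(C2Cc3ccccc3O2)n2cnnn2)c(Cl)c1`, differs from compound 3 in one place: 1H-tetrazol-1-yl in place of 1H-1,2,4-triazol-1-yl on a saturated chain carbon bound to an aromatic carbon and a saturated ring carbon. Among the measured compounds shown here, the only measured step, a 3.1-fold higher number from compound 1 to compound 2 (0.49 log units; beyond the scatter), concerns a change on an aromatic carbon, not the five-membered ring, so no measured step bears on this change. The expectation therefore rests on no direct evidence, and a step of a 2.3-fold higher number from compound 3 to compound 4 (0.36 log units; beyond the scatter) is estimated, toward a weaker result but with wide uncertainty. Compound 4 is expected to give about 2000 nM, within a range from 600 nM to 7000 nM.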

Compound 4, half-maximal inhibitory concentration: 52000 nM
Compound 4: the middle estimate sits 26-fold (1.41 log units) below what was measured, outside the stated range (above it).
By their numbers in this assay, from the lowest: compound 1; then compounds 2 and 3 (each within the scatter of the next); then compound 4.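

Among the compounds shown here, the five-membered ring on the saturated chain carbon bound to an aromatic carbon and a saturated ring carbon proved to matter far more than the earlier compounds could show. For the compounds shown here, replacing 1H-1,2,4-triazol-1-yl with 1H-tetrazol-1-yl keeps the count of 5 heavy atoms and exchanges just one ring carbon for a nitrogen, yet in this assay it produces the largest step so far (a 59-fold higher number from compound 3 to compound 4 (1.77 log units; beyond the scatter)), well beyond the earlier change on an aromatic carbon (a 3.1-fold higher number from compound 1 to compound 2 (0.49 log units; beyond the scatter)). Nothing measured here explains why so small an exchange weakens inhibition this much.

From the compounds shown here alone, it remains open whether the same exchange would cost as much with the fluoro group of compound 1 on the aromatic ring. Also open, going by these compounds, is how an imidazol-1-yl ring or a simple amine would behave at this position.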